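This account rests on a few compounds, and the source may have more. Where it says the series, first, only, none or still open, it means among the compounds named here.

Compound 1, `COc1ccc(-c2cnc3nc(N)nc(NCc4cccs4)c3n2)cc1OC`: 4100 nM
Compound 2, `COc1ccc(-c2cnc3nc(N)nc(NC4CCCC4)c3n2)cc1OC`: 800 nM

In a functional assay on cells (T-cell, Homo sapiens) for inhibition (a lower number here means a stronger inhibitor, a higher number a weaker inhibitor), compound 2 gives the lowest of the two numbers, separated from compound 1 by a 5.1-fold lower number from compound 1 to compound 2 (0.71 log units; beyond the scatter). Compound 3, `COc1ccc(-c2cnc3nc(N)nc(N4CCC(C)CC4)c3n2)cc1OC`, differs from compound 2 by 4-methylpiperidin-1-yl in place of cyclopentylamino on an aromatic carbon. Among the measured compounds shown here, the only measured step, from compound 1 to compound 2, also altered the group on that aromatic carbon, but by a change of another kind, so it gives no direct guide. With the ring kept saturated but the donor gone, compound 3 is expected to show a 1.9-fold higher number from compound 2 to compound 3 (0.27 log units; within the scatter), hardly beyond the scatter. Compound 3 is estimated at 1500 nM, between 500 nM and 5000 nM.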

Compound 3, half-maximal inhibitory concentration: 800 nM
Beside the measured number, compound 3's estimate is 1.9-fold (0.27 log units) above it; measured number inside the range.
By their numbers in this assay, from the lowest: compounds 2 and 3 (each within the scatter of the next); then compound 1.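

In this assay, the amino hydrogen-bond donor of cyclopentylamino is not needed at this aromatic carbon: there is no change at the digits printed from compound 2 to compound 3 (within the scatter) even though 4-methylpiperidin-1-yl has no donor and a six-membered ring. The second saturated ring also improves on the thiophene-bearing group, with a 5.1-fold lower number from compound 1 to compound 3 (0.71 log units; beyond the scatter) matching the earlier cyclopentyl gain. No evidence here accounts for these results.

From the compounds shown here alone, it remains open whether the 4-methyl group contributes, as a plain piperidin-1-yl would show. A morpholin-4-yl or an open-chain dimethylamino group at this carbon also remains untested in the compounds shown.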